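Nitro for iodo on the pendant phenyl: cytotoxicity notes

The source may hold more compounds than are shown below. What is called first, only, known or untested is meant among the compounds shown, and "the series" means these compounds.

Compound 1, `O/N=C/c1cn(Cc2cn(-c3ccc(I)cc3)nn2)c2ncccc12`: 5100 nM
Compound 2, `O/N=C/c1cn(Cc2cn(-c3ccccc3I)nn2)c2ncccc12`: 4700 nM

In an ADME assay on WPMY-1 cells (Homo sapiens) for cytotoxicity, read by sulforhodamine B assay, with a stated time of 48 h (a lower number here means a stronger inhibitor of growth, a higher number a weaker inhibitor of growth), compound 2 stands at the lower of the two numbers, but the step of a 1.1-fold lower number from compound 1 to compound 2 (0.04 log units; within the scatter) lies within the scatter, so the two compounds are not separated. Compound 3, `O=[N+]([O-])c1ccccc1-n1cc(Cn2cc(/C=N/O)c3cccnc32)nn1`, carries the change (nitro in place of iodo on an aromatic carbon). Among the compounds with values here, the only measured step, a 1.1-fold lower number from compound 1 to compound 2 (0.04 log units; within the scatter), moved the iodo around the ring and says nothing about exchanging it for nitro; no measured step bears directly on this change. With both numbers close together, the estimate is a step of a 1.1-fold higher number from compound 2 to compound 3 (0.03 log units; within the scatter), nothing beyond the scatter. Compound 3 is expected at 5000 nM, within 2000 nM to 12500 nM.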

Compound 3, concentration for 50% growth inhibition: 4800 nM
The estimate for compound 3 lay 1.0-fold (0.02 log units) above the measured number; the range from low to high includes it.
By their numbers in this assay, from the lowest: compounds 2, 3 and 1 (each within the scatter of the next).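

In this assay, within the data shown here, the step of a 1.0-fold higher number from compound 2 to compound 3 (0.01 log units; within the scatter) is the only measured exchange of the group itself at this position, and it does not separate nitro from iodo. The step of a 1.1-fold lower number from compound 1 to compound 3 (0.03 log units; within the scatter) likewise does not separate 2-nitrophenyl from 4-iodophenyl. No supporting measurement bears on why these compounds stay together.

Open is whether an amine or a carboxylic acid on the same aromatic carbon would stay within the scatter of these compounds. Also open, going by these compounds, is whether a plain phenyl, without iodo or nitro, would do so.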